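The source may hold more compounds than are shown below. What is called first, only, known or untested is meant among the compounds shown, and "the series" means these compounds.

Measured compounds:
Compound 1, `CC1=C(C(=O)Nc2ccc(F)cc2)C(c2ccc([N+](=O)[O-])cc2)N=C(SCc2ccccc2Cl)N1`, 18.5%
Compound 2, `CC1=C(C(=O)Nc2ccc(F)cc2)C(c2ccc([N+](=O)[O-])cc2)N=C(SCc2cccc(Cl)c2)N1`, 18.5%
Compound 3, `CC1=C(C(=O)Nc2ccc(Br)cc2)C(c2ccc(Cl)cc2Cl)N=C(SCc2ccccc2Cl)N1`, 36.4%

In a functional assay on the whole organism (artery, strain albino) with Rattus norvegicus as the target, with a stated time of 300 min, at a dose of 10 mg/kg by the oral route (on this read-out higher numbers stand for more inhibition at the one dose given (going by the name of the read-out) and lower numbers for less inhibition), compound 1 and compound 2 give numbers that sit together, and the change between them, (3-chlorophenyl in place of 2-chlorophenyl on a saturated chain carbon bound to a sulfur), leaves the read-out where it was: no change at the digits printed from compound 1 to compound 2 (within the scatter). Compound 3 stands highest of the three, and its gap to compound 1 and to compound 2 is beyond the scatter. The difference between the core of compound 3 and the core of compound 1 is not broken down here.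

Compound 4, `CC1=C(C(=O)Nc2ccc(Br)cc2)C(c2ccc(Cl)cc2Cl)N=C(SCc2cccc(Cl)c2)N1`, has not yet been measured in this assay. It differs from compound 3 by 3-chlorophenyl in place of 2-chlorophenyl on a saturated chain carbon bound to a sulfur, the same change at the same place as from compound 1 to compound 2. Because no change at the digits printed from compound 1 to compound 2 (within the scatter) showed no movement, the step from compound 3 to compound 4 is expected to be small, a number 0.4 percentage points lower from compound 3 to compound 4 (within the scatter). Compound 4 is therefore estimated at 36%, with a range from 24% to 48%.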

Compound 4, a percentage reported as inhibition, in the whole organism at one dose (the size of the read-out at that dose, not a potency): 18.5%
The estimate for compound 4 lay 17.5 percentage points above the measured number, outside the stated range (below it).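

In this assay, 3-chlorophenyl in place of 2-chlorophenyl on a saturated chain carbon bound to a sulfur gives a number 17.9 percentage points lower from compound 3 to compound 4 (beyond the scatter). This change therefore does not carry over unchanged from one core to the other: the same change on two cores in this assay, no change at the digits printed (within the scatter) from compound 1 to compound 2 and a number 17.9 percentage points lower (beyond the scatter) from compound 3 to compound 4, 17.9 percentage points apart, beyond the scatter of two such steps What the change does to the read-out depends on the core in these four compounds, but the two cores differ in more than one place, and nothing shown tells which difference matters.

On these data alone, it remains open whether a core carrying only one of those differences would behave like the core of compound 1 or the core of compound 3. Also open, as far as these compounds go, is what an unsubstituted benzyl or a longer chain on the sulfur would give in this assay.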